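Swapping the Aryl Amide Cap for a Methylisoxazole

A few compounds are considered here, and "the series" means these few. Any claim that something is new, unique, unknown or untested is made for them only; others in the source may bear on it.

Three compounds share one core and differ only in the group on the amide-type nitrogen. In an assay on isolated protein for inhibition of histone deacetylase 8 (Homo sapiens), with a stated time of 1 h (on this read-out higher numbers stand for weaker inhibition and lower numbers for stronger inhibition), compound 3 `Cc1cc(Br)ccc1NC(=O)COc1ccc2cc(/C=C3/SC(=O)NC3=O)ccc2c1` gives 7400 nM, the lower of the two measured numbers, while compound 1 `CCOc1ccc2nc(NC(=O)COc3ccc4cc(/C=C5/SC(=O)NC5=O)ccc4c3)sc2c1` gives 17000 nM. Compound 2 `O=C(COc1ccc2cc(/C=C3/SC(=O)NC3=O)ccc2c1)Nc1ccccn1` reaches only > 50000 nM, which is a limit of this assay rather than a number. For the measured compounds named here, the one measured step bearing on the next change is an at least 6.7-fold lower number from compound 2 to compound 3 (0.82 log units; beyond the scatter), where a carbon-only ring replaced a nitrogen-containing ring; its stated size rests on (the limit of > 50000 nM in this assay, at which 1 of the 3 values shown sits). Compound 4 `Cc1cc(NC(=O)COc2ccc3cc(/C=C4/SC(=O)NC4=O)ccc3c2)no1` carries 5-methyl-1,2-oxazol-3-yl in place of 4-bromo-2-methylphenyl on an amide-type nitrogen. This change runs back from a carbon-only ring to a ring with hetero atoms, so by analogy a modest rise in number is expected, a 3.4-fold higher number from compound 3 to compound 4 (0.53 log units; beyond the scatter). Compound 4 is therefore estimated at 25000 nM, within 9000 nM to 60000 nM.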

Compound 4, half-maximal inhibitory concentration: > 50000 nM
Compound 4: no number, only a limit; the forecaster's own chance of this, stated with the estimate: 30%; middle value at least 2.0-fold (0.30 log units) away from the limit.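

In this assay the change back to a ring with hetero atoms costs at least as much as the earlier change gained: an at least 6.7-fold higher number from compound 3 to compound 4 (0.82 log units; beyond the scatter). Compound 2 and compound 4 thus both trail compound 3, although the group of compound 1 also holds hetero atoms and compound 1 gives 17000 nM. The step between compound 2 and compound 4 cannot be read, and the step to compound 4 gives only a minimum size: the limit of > 50000 nM in this assay, at which 2 of the 4 values shown sit.

Still open, as far as these compounds go, is whether the bromine or the methyl of compound 3 matters more. A plain phenyl ring, or a phenyl ring carrying a carboxylic acid, would be further groups to try at this place.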